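The compounds below may be only part of what the source reports. "The series", "measured", "known", "first", "only" and "open" are said of these compounds alone.

Measured compounds in a functional assay on A549 cells (Homo sapiens) for antiproliferative activity, read by MTT assay; on this read-out higher numbers stand for weaker inhibition and lower numbers for stronger inhibition:
compound 1 `Cn1c(=O)c(=O)n(C2CCCC2)c2nc(N/N=C/c3cc(C(F)(F)F)c(O)c(C(F)(F)F)c3)ncc21`, compound 1 gives 22900 nM
compound 2 `Cc1cc(C)c(/C=N/Nc2ncc3c(n2)n(C2CCCC2)c(=O)c(=O)n3C)c(C)c1`, compound 2 gives 12000 nM
compound 3 `Cn1c(=O)c(=O)n(C2CCCC2)c2nc(N/N=C/c3cc(C(F)(F)F)cc(C(F)(F)F)c3)ncc21`, compound 3 gives 3230 nM

Compound 2 has the second highest number of the three. Against compound 1 its value is within the scatter, so no order between them can be read. Compound 3 has a lower number than compound 2, and the gap is beyond the scatter. For the measured compounds named here, the one measured step is a 7.1-fold lower number from compound 1 to compound 3 (0.85 log units; beyond the scatter), a change of a hydroxy to hydrogen on an aromatic carbon.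

Compound 4 `Cn1c(=O)c(=O)n(C2CCCC2)c2nc(N/N=C/c3ccccc3Cl)ncc21` is not yet measured. It differs from compound 2 by 2-chlorophenyl in place of 2,4,6-trimethylphenyl on a carbon with a double bond to nitrogen. No measured step touches this part of the structure, so nothing bears directly on it; the only thing shown is that the number in this assay changes with the substituents on the aryl ring across compounds 1, 2 and 3. With no guide, the expectation is a step of a 1.3-fold lower number from compound 2 to compound 4 (0.12 log units; within the scatter) of no clear direction. Compound 4 is estimated at 9000 nM, with a range from 2500 nM to 32000 nM.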

Compound 4, half-maximal inhibitory concentration: 9860 nM
Compound 4: middle estimate off by 1.1-fold (0.04 log units), on the low side, and the stated range covers the measured number.
By their numbers in this assay, from the lowest: compound 3; then compounds 4, 2 and 1 (each within the scatter of the next, the first and the last beyond it).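

In this assay, 2-chlorophenyl in place of 2,4,6-trimethylphenyl on a carbon with a double bond to nitrogen gives a 1.2-fold lower number from compound 2 to compound 4 (0.09 log units; within the scatter). The earlier step changed only a hydroxy on the aryl ring, whereas this one exchanges the whole aryl group, and methyl groups give way to chlorine without a readable shift in the number, so no order can be set between these two compounds. Nothing available bears on why this exchange leaves the number within the scatter.

As far as these compounds go, it remains open whether unsubstituted phenyl, or an aryl ring carrying an amine or a carboxylic acid, would move the number beyond the scatter at this place. A longer alkyl chain in place of the aryl group is also untested territory in the compounds shown.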